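A few compounds are considered here, and "the series" means these few. Any claim that something is new, unique, unknown or untested is made for them only; others in the source may bear on it.

Compound 1 `Cc1ccc(-c2nn(-c3ccc(Cl)cc3Cl)cc2C(=O)Nc2ccc(C)c(S(=O)(=O)N3CCOCC3)c2)cc1` gives 1240 nM.
Compound 2 `COc1cccc(-c2nn(C(C)C)cc2C(=O)Nc2ccc(C)c(S(=O)(=O)N3CCOCC3)c2)c1` gives 3490 nM.
Compound 3 `COc1cccc(Cn2cc(CNc3ccc(C)c(S(=O)(=O)N4CCOCC4)c3)c(C(C)C)n2)c1` gives 27800 nM.

These three numbers come from an assay on HEK-293T cells for inhibition of Bile acid receptor (Homo sapiens), read by a beta-lactamase reporter, with a stated time of 16 h; on this read-out lower numbers stand for stronger inhibition and higher numbers for weaker inhibition. Among them compound 1 stands lowest and therefore strongest: compound 2 is nearest, with a number beyond the scatter above it, and compound 3 is furthest, far beyond the scatter. Compound 4 `Cc1ccc(-c2nn(-c3ccccc3)cc2C(=O)Nc2ccc(C)c(S(=O)(=O)N3CCOCC3)c2)cc1` has not yet been measured. It differs from compound 1 in one place: phenyl in place of 2,4-dichlorophenyl on an aromatic nitrogen. Among the compounds with values here, no measured pair in this set shows what this change does on its own, so any expectation rests on the spread of the three numbers. Compound 1 carries the two chlorines and has the lowest number, while compound 2 carries a different group on that ring nitrogen and gives 3490 nM, a weaker result. The step from compound 1 to compound 4 is therefore expected to go toward a higher number, by a modest amount near the edge of the scatter, a 2.0-fold higher number from compound 1 to compound 4 (0.30 log units; within the scatter). For compound 4 in this assay the expected value is 2500 nM, with a range from 900 nM to 7000 nM.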

Compound 4, half-maximal inhibitory concentration: 2620 nM
Beside the measured number, compound 4's estimate is 1.0-fold (0.02 log units) below it, within the range that was stated.
By their numbers in this assay, from the lowest: compound 1; then compounds 4 and 2 (each within the scatter of the next); then compound 3.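

In this assay, replacing the 2,4-dichlorophenyl on the aromatic nitrogen with plain phenyl gives a 2.1-fold higher number from compound 1 to compound 4 (0.32 log units; beyond the scatter), a modest step toward weaker inhibition. Within the data shown here, this is the first reading of this position with nothing else in the molecule changing, and it shows that the two chlorines together make a real but small difference. Compound 4 also shows that the chlorines are not needed for a measurable inhibition, and no data at hand say why removing them has this effect.

From the compounds shown here alone, it remains open whether a single chlorine would account for the whole step, or whether a fluorine, a trifluoromethyl or a pyridine ring at this place would do as well. Compound 2 also differs in the group on the other ring, so it cannot isolate the effect of the group on this nitrogen.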